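Adding a methoxymethyl arm to a quinoxaline dioxide ester

This account rests on a few compounds, and the source may have more. Where it says the series, first, only, none or still open, it means among the compounds named here.

Compound 1 `COC(=O)c1c(C)[n+]([O-])c2cc(Cl)c(Cl)cc2[n+]1[O-]` is tested in an ADME assay on Vero cells (Chlorocebus sabaeus) for cytotoxicity (on this read-out higher numbers stand for weaker inhibition and lower numbers for stronger inhibition), where compound 1 gives 1.68 ug/mL. Compound 3 `CCc1c(C(=O)OC)[n+]([O-])c2cc(F)c(F)cc2[n+]1[O-]` gives 1.2 ug/mL in this assay, a number within the usual scatter of that of compound 1, so the two cannot be ordered. Compound 2 `CCc1c(C(=O)OC)[n+]([O-])c2cc(C)c(C)cc2[n+]1[O-]` reaches only a limit of this assay, > 62.5 ug/mL, a value that is not a number; (the limit of > 62.5 ug/mL in this assay, at which 1 of the 3 values shown sits). Compound 4 `COCCc1c(C(=O)OC)[n+]([O-])c2cc(Cl)c(Cl)cc2[n+]1[O-]` differs from compound 1 by methoxymethyl in place of hydrogen on a saturated chain carbon bound to an aromatic carbon. Among the measured compounds shown here, no measured pair shows this change, so its effect is unknown. Compound 4 is expected to sit close to compound 1, with the step of a 1.8-fold higher number from compound 1 to compound 4 (0.25 log units; within the scatter) expected to stay near the scatter. Compound 4 is estimated at 3 ug/mL, between 0.8 ug/mL and 15 ug/mL.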

Compound 4, half-maximal inhibitory concentration: 4.5 ug/mL
The estimate for compound 4 lay 1.5-fold (0.18 log units) below the measured number; low and high end bracket the measured number.
By their numbers in this assay, from the lowest: compounds 3 and 1 (each within the scatter of the next); then compound 4. At a limit, above all of these: compound 2.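

In this assay, among the compounds shown here, methoxymethyl in place of hydrogen on a saturated chain carbon bound to an aromatic carbon gives a 2.7-fold higher number from compound 1 to compound 4 (0.43 log units; beyond the scatter) and so weaker inhibition of the cells, the first step at this position that can be read. The change is modest, and compound 4 still gives a measured number rather than a limit. Nothing shown explains the step.

This one pair cannot separate the effect of the ether oxygen from that of the longer chain. Going by these compounds, whether a plain propyl chain or an amine at the end of the chain would give a similar step remains open.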